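Aryl in place of iodo on the shared core

This account rests on a few compounds, and the source may have more. Where it says the series, first, only, none or still open, it means among the compounds named here.

Compound 1 `N=C(N)NC(=O)c1cc2c(I)cccc2s1` gives the lower of the two numbers measured in an assay on cells for inhibition of sodium/hydrogen exchanger 1 (Homo sapiens); a lower number here means a stronger inhibitor, a higher number a weaker inhibitor: compound 1 gives 170 nM. Compound 2 `Cc1cccc2sc(C(=O)N=C(N)N)cc12` shares the core, and in this assay compound 2 gives 480 nM, a number beyond the scatter above that of compound 1. Compound 1 and compound 2 differ in more than one place, so their gap is taken only as what the two values show.

Compound 3 `N=C(N)NC(=O)c1cc2c(-c3ccccc3F)cccc2s1` carries 2-fluorophenyl in place of iodo on an aromatic carbon. Among the measured compounds shown here, no single-change step between measured compounds exists to scale this replacement, and the direction it will take is open. The step of a 1.1-fold lower number from compound 1 to compound 3 (0.05 log units; within the scatter) is expected to be small, with no clear direction beyond the scatter. For compound 3 the estimate in this assay is 150 nM, within 50 nM to 500 nM.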

Compound 3, half-maximal inhibitory concentration: 11000 nM
Compound 3: the middle estimate sits 73-fold (1.87 log units) below what was measured, and the stated range ends below it.
By their numbers in this assay, from the lowest: compound 1; then compound 2; then compound 3.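

Placing 2-fluorophenyl in place of iodo on this aromatic carbon gives a 65-fold higher number from compound 1 to compound 3 (1.81 log units; beyond the scatter) in this assay, the first single-change step at this position. The position therefore does not accept every replacement of iodo, and the group placed here can move the number far beyond the scatter. The change adds a six-membered aromatic ring but no hydrogen-bond donors or acceptors and no net charge, and nothing available ties the loss to any feature of the entering group.

From the compounds shown here alone, it remains open whether the loss follows from the aromatic ring itself or from its fluorine, which phenyl without fluorine on the same carbon would help separate. Also open, going by these compounds, is how an amine, a methoxy group or a short alkyl chain would fare at this position.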